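This account rests on a few compounds, and the source may have more. Where it says the series, first, only, none or still open, it means among the compounds named here.

Measured in an assay on HL-60 cells for agonist activity at vitamin D3 receptor (Homo sapiens), read by microscopy, with a stated time of 96 h; a lower number here means that less compound is needed, a higher number that more compound is needed for the effect:
compound 1 `CCN(CC)CCCNC(=O)c1ccc(C(CC)(CC)c2ccc(OCC(O)C(C)(C)C)c(C)c2)n1CC`: 66 nM
compound 2 `CCn1c(C(=O)N(C)CCC#N)ccc1C(CC)(CC)c1ccc(OCC(O)C(C)(C)C)c(C)c1`: 1960 nM
compound 3 `CCOc1ccc(NC(=O)c2ccc(C(CC)(CC)c3ccc(OCC(O)C(C)(C)C)c(C)c3)n2CC)cc1`: 630 nM

Compound 3 stands second highest of the three in this assay; compound 2 is its nearest neighbour with a higher number, compound 1 lies furthest from it with a lower number. All three share one core and differ only in the group on the carbonyl carbon. Compound 4 `CCn1c(C(=O)Oc2ccc(CCO)cc2)ccc1C(CC)(CC)c1ccc(OCC(O)C(C)(C)C)c(C)c1` carries the next change there: a group of 10 heavy atoms (8 carbon, 2 oxygen; one six-membered aromatic ring of carbon only) in place of a group of 10 heavy atoms (8 carbon, 1 nitrogen, 1 oxygen; one six-membered aromatic ring of carbon only), on a carbonyl carbon. The amide-type nitrogen of compound 3 gives way to an oxygen link, while an aromatic ring and one hydrogen-bond donor remain.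

Within the data shown here, the steps that bear on this position are a 9.5-fold higher number from compound 1 to compound 3 (0.98 log units; beyond the scatter) and a 3.1-fold lower number from compound 2 to compound 3 (0.49 log units; beyond the scatter), both modest, and a 30-fold higher number from compound 1 to compound 2 (1.47 log units; beyond the scatter), which was large. Among the measured compounds shown here, none of them exchanges the amide-type nitrogen itself; the closest precedent is compound 2, which lacks the amide hydrogen and gives the highest number of the three. A modest step in this assay is therefore expected, more likely towards a higher number than a lower one.

Compound 4 is expected to give about 1000 nM, within 250 nM to 4000 nM. The expected step of a 1.6-fold higher number from compound 3 to compound 4 (0.20 log units; within the scatter) is thus modest and lies at the edge of the scatter.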

Compound 4, half-maximal effective concentration: 5100 nM
Beside the measured number, compound 4's estimate is 5.1-fold (0.71 log units) below it, and the stated range ends below it.
By their numbers in this assay, from the lowest: compound 1; then compound 3; then compound 2; then compound 4.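

In this assay, replacing the amide-type nitrogen link with an oxygen link, within a group that also differs elsewhere, gives an 8.1-fold higher number from compound 3 to compound 4 (0.91 log units; beyond the scatter), even though the aromatic ring and the hydrogen-bond donor count stay the same. The new group also gives the highest number of the series, with a 2.6-fold higher number from compound 2 to compound 4 (0.42 log units; beyond the scatter) and a 77-fold higher number from compound 1 to compound 4 (1.89 log units; beyond the scatter). An aromatic ring on this carbonyl carbon therefore does not by itself keep the number low, and the 3-(diethylamino)propyl amide of compound 1 remains the lowest of the four.

Still open, going by these compounds, is how much of the step belongs to the oxygen link and how much to the rest of the group, as well as how a piperidine amide or a carboxylic acid at this carbonyl carbon would compare with compound 1. No measurement here gives a cause for any of these steps.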